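This account rests on a few compounds, and the source may have more. Where it says the series, first, only, none or still open, it means among the compounds named here.

Working notes on the series. Compound 1 `O=C(O)c1cccc(NC(=O)c2ccc(OCCCCc3ccccc3)cc2)c1` reaches 34% in an assay on HeLa cells for agonist activity at Bile acid receptor (Homo sapiens), read by a luciferase reporter; a higher number here means a larger maximal response, a lower number a smaller maximal response. For the measured compounds named here, compound 2 `O=C(O)c1cccc(NC(=O)c2ccc(OCc3ccccc3)cc2)c1` gives 20% in this assay, the lower of the two numbers measured so far; the only measured step, a number 14 percentage points lower from compound 1 to compound 2 (beyond the scatter), went with phenyl in place of 3-phenylpropyl on a saturated chain carbon bound to an oxygen on an aromatic ring.

Compound 3 `O=C(O)c1cccc(NC(=O)c2ccc(Oc3ccccc3)cc2)c1` has not been measured in this assay. Its change from compound 2 is phenyl in place of benzyl on an oxygen on an aromatic ring; one bond further out it reads benzyloxy to phenoxy. Going by the values given here, the only step that bears on it is a number 14 percentage points lower from compound 1 to compound 2 (beyond the scatter), where phenyl entered for 3-phenylpropyl on the carbon bound to that oxygen and the maximal response fell modestly. The step to compound 3 replaces benzyl by phenyl on the same oxygen, so a further modest fall in this assay, or no step beyond the scatter, is expected; nothing measured points to a rise.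

Compound 3 is therefore estimated at 14% in this assay, with a range from 4% to 28%. The expected step is a number 6 percentage points lower from compound 2 to compound 3 (within the scatter).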

Compound 3, largest response reached (Emax), in percent of the reference or control that the assay uses: 35%
Compound 3: the middle estimate sits 21 percentage points below what was measured; measured number above the stated range.
By their numbers in this assay, from the lowest: compound 2; then compounds 1 and 3 (each within the scatter of the next).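

For the compounds shown here, the benzyloxy to phenoxy change reverses the direction expected from the only earlier step: phenyl in place of benzyl on the oxygen goes with a number 15 percentage points higher from compound 2 to compound 3 (beyond the scatter) in this assay. The maximal response therefore does not fall steadily as the group on this oxygen gets smaller, and compound 2 goes against any such trend, standing lowest and beyond the scatter of both other compounds. Compound 1 and compound 3 lie within the scatter of each other despite the different groups on this oxygen, so a large response here does not depend on the longer chain of compound 1, and no measurement at hand explains why the benzyl compound stands lowest.

Going by these compounds, whether the low response is confined to benzyl remains open, since a 2-phenylethyl or 3-phenylpropyl group on the same oxygen would show how the response changes between the groups seen so far. On these data alone, it is also open whether the response of compound 3 depends on the phenyl ring itself, which a pyridyl or cyclohexyl group in its place would test.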